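One Hydroxy Group Less: Expecting the Cytotoxicity of Compound 3

The source may hold more compounds than are shown below. What is called first, only, known or untested is meant among the compounds shown, and "the series" means these compounds.

Compound 1 `CCCCC/C=C/C=C/C=C/c1c(O)ccc(O)c1C(=O)O` has been measured in a functional assay on KB cells (Homo sapiens) for cytotoxicity, read by colorimetric assay (on this read-out higher numbers stand for weaker inhibition and lower numbers for stronger inhibition), where compound 1 gives 4200 nM. Its partner compound 2 `CCCCC/C=C/C=C/C=C\c1c(O)ccc(O)c1C(=O)O` shares every atom and bond, and in this assay compound 2 gives 21000 nM. Within the data shown here, the only measured step, a 5.0-fold higher number from compound 1 to compound 2 (0.70 log units; beyond the scatter), rests on (the fact that compounds 1 and 2 differ only in the configuration as drawn). Compound 1 thus stands at the lower of the two numbers. Compound 3 `CCCCC/C=C/C=C/C=C/c1cccc(O)c1C(=O)O` differs from compound 1 in a single place: hydrogen in place of hydroxy on an aromatic carbon. Among the measured compounds shown here, no measured step touches this kind of change; the one step known concerns configuration alone and offers no direct guide to the loss of a hydroxy group. With nothing to point in either direction, compound 3 is expected to show a step of a 1.2-fold higher number from compound 1 to compound 3 (0.08 log units; within the scatter) that stays within the usual scatter, though with a wide range. Compound 3 is estimated at 5000 nM, between 1500 nM and 20000 nM.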

Compound 3, half-maximal inhibitory concentration: 13000 nM
Compound 3: the middle estimate sits 2.6-fold (0.41 log units) below what was measured, and the stated range covers the measured number.
By their numbers in this assay, from the lowest: compound 1; then compounds 3 and 2 (each within the scatter of the next).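

The hydroxy group on this aromatic carbon, ortho to a large group, meta to a carboxy group and para to a hydroxy group, matters to the result. In this assay, hydrogen in its place gives a 3.1-fold higher number from compound 1 to compound 3 (0.49 log units; beyond the scatter), so losing this one group weakens inhibition by more than the usual scatter. Until now only a change of double-bond configuration had moved the number, whereas this step shows that a change on the aromatic ring moves it too, though the one available fact concerns configuration and gives no reason for this effect.

As far as these compounds go, whether a methoxy group, a fluorine atom or an amine at this place would keep the number close to that of compound 1 stays open. So does the effect of the same replacement at the remaining hydroxy group on the ring.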